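The source may report more compounds than this note shows. Statements on the series, on what has been measured and on what is new or still open speak of the compounds shown alone.

Working notes on a set of nitrooxy-bearing esters of a shared core, read in a physicochemical assay for lipophilicity, read by HPLC, measured as octanol-water partition, at pH 7; a higher number here means a more lipophilic compound, a lower number a more polar compound. Compound 1 `Cc1cc(OC(=O)CCCCCO[N+](=O)[O-])n(-c2ccccc2)n1` gives 3.79 in this assay. Compound 2 `Cc1cc(OC(=O)CCCC(CO[N+](=O)[O-])O[N+](=O)[O-])n(-c2ccccc2)n1` gives 3.95 in this assay. Compound 3 `Cc1cc(OC(=O)c2ccc(OCC(CO[N+](=O)[O-])O[N+](=O)[O-])cc2)n(-c2ccccc2)n1` gives 5.14 in this assay, the highest of the three numbers, beyond the scatter from both of the others. Compound 3 and compound 2 differ in more than one place, so the difference between the two cores is not broken down here; the two values simply show compound 3 standing well above compound 2.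

One structural change is covered by a measured pair. Going from compound 2 to compound 1 the change is hydrogen in place of nitrooxy on a saturated chain carbon bound to two saturated chain carbons, and the step that it made is a number 0.16 log units lower from compound 2 to compound 1 (within the scatter).

The same change is now applied on the core of compound 3 to reach compound 4 `Cc1cc(OC(=O)c2ccc(OCCCO[N+](=O)[O-])cc2)n(-c2ccccc2)n1`, not yet measured: hydrogen in place of nitrooxy on a saturated chain carbon bound to two saturated chain carbons. The place of the change is described in the same words in both pairs, so the two occurrences are taken as the same change, although they sit on two different cores. For the measured compounds named here, the measured step of a number 0.16 log units lower from compound 2 to compound 1 (within the scatter) is the only guide available for its size. On that basis the expected step is a number 0.16 log units lower from compound 3 to compound 4 (within the scatter), a step of about the same size and in the same direction as the measured one. Compound 4 is estimated at 4.98 in this assay, with a range from 4.65 to 5.3.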

Compound 4, partition coefficient: 4.74
The estimate for compound 4 lay 0.24 log units above the measured number; the range from low to high includes it.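

In this assay, putting hydrogen in place of nitrooxy on a saturated chain carbon bound to two saturated chain carbons gives a number 0.40 log units lower from compound 3 to compound 4 (beyond the scatter), while the same change on the other core gave a number 0.16 log units lower from compound 2 to compound 1 (within the scatter). For the compounds shown here, the change therefore reads clear of the scatter on one core and not on the other, so the earlier step alone did not fix the size of the later one, and with only one pair on each core, these readings do not show whether the core sets the size of the step or how far the step can be trusted on a further core. No supporting measurement bears on why the two pairs read as they do.

The compounds shown leave open how this change would read on a third core, and whether a similar step would appear with a longer chain carrying the nitrooxy. They also leave open what would follow if an amine or a carboxylic acid entered in place of the hydrogen on that same chain carbon.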